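The source may hold more compounds than are shown below. What is called first, only, known or untested is meant among the compounds shown, and "the series" means these compounds.

Compound 1, `CCN(CC)CN1C(=O)/C(=N\c2nc3ccc(C)cc3s2)c2ccccc21`, in a functional assay on MCF7 cells (Homo sapiens) for cytotoxicity, read by sulforhodamine B assay, with a stated time of 48 h (a lower number here means a stronger inhibitor of growth, a higher number a weaker inhibitor of growth), gives 74800 nM. Compound 2, `Cc1ccc2nc(/N=C3\C(=O)N(CN4CCCCC4)c4ccccc43)sc2c1`, in this assay gives 37800 nM. Compound 3, `O=C1C(=O)N(CN2CCCCC2)c2cccc(Br)c21`, in this assay gives 31500 nM.

Compounds 1 and 2 share one core and differ in a single place: diethylamino in place of piperidin-1-yl on a saturated chain carbon bound to an amide-type nitrogen in a ring. That change brought a 2.0-fold higher number from compound 2 to compound 1 (0.30 log units; within the scatter), so the two values sit within the scatter of each other and no order between them is claimed. Compound 3 has a different core; its value stands within the scatter of compound 2 and beyond it against compound 1. How the core of compound 3 differs from that of compound 2 is not broken down here.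

Compound 4, `CCN(CC)CN1C(=O)C(=O)c2c(Br)cccc21`, is not yet measured in this assay. It stands to compound 3 as compound 1 stands to compound 2: diethylamino in place of piperidin-1-yl on a saturated chain carbon bound to an amide-type nitrogen in a ring. The place is described in the same words for both pairs, so this is the same change on a second core. Among the compounds shown, it has been made once before, and there it stayed within the scatter. The expectation for compound 4 therefore rests on that single earlier step, with the caution that a change seen on one core need not carry over to another. Compound 4 is expected to give 50000 nM in this assay, within a range of 20000 nM to 120000 nM, which means a step of a 1.6-fold higher number from compound 3 to compound 4 (0.20 log units; within the scatter) is estimated, sized after a 2.0-fold higher number from compound 2 to compound 1 (0.30 log units; within the scatter).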

Compound 4, concentration for 50% growth inhibition: 20200 nM
Compound 4: middle estimate off by 2.5-fold (0.39 log units), on the high side; low and high end bracket the measured number.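

Carried onto the second core, replacing piperidin-1-yl with diethylamino on a saturated chain carbon bound to an amide-type nitrogen in a ring brought a 1.6-fold lower number from compound 3 to compound 4 (0.19 log units; within the scatter) in this assay, so these two values stand within the scatter of each other and no order between them is claimed. Set beside the earlier step, the change did not give the same result on both cores, as the two steps lie further apart than the scatter of such steps would account for: the same change on two cores in this assay, a 2.0-fold higher number (0.30 log units; within the scatter) from compound 2 to compound 1 and a 1.6-fold lower number (0.19 log units; within the scatter) from compound 3 to compound 4, 3.1-fold (0.49 log units) apart, beyond the scatter of two such steps

This shows that the size and direction of the step seen on one core could not simply be transferred to the other, but it does not show that the change truly raises the number on one core or lowers it on the other, since each step taken alone stays within the scatter, and two pairs give no rule for the series and no reason for the gap.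

The compounds shown leave open how a morpholine or a dimethylamino group at the same place would read in this assay, and whether a longer chain to the amine would behave alike on both cores. They also leave open whether the same change would hold up on a third core, for instance one with chlorine in place of the bromine.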